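Swapping bromo for hex-1-yn-1-yl

The source may report more compounds than this note shows. Statements on the series, on what has been measured and on what is new or still open speak of the compounds shown alone.

Going by the values given here, in a physicochemical assay for lipophilicity, at pH 7.4 (a lower number here means a more polar compound, a higher number a more lipophilic compound), compound 3 (`COc1cc2[nH]c(C)c(Br)c(=O)c2cc1Cl`) gives 0, the lowest of the three numbers so far. Compound 2 (`COc1cc2[nH]c(C)c(C(C)C)c(=O)c2cc1Cl`) gives 2.84, and compound 1 (`CCCCC#Cc1c(C)[nH]c2ccc(Cl)cc2c1=O`) gives 2.98. Compound 4 (`CCCCC#Cc1c(C)[nH]c2cc(OC)c(Cl)cc2c1=O`) has hex-1-yn-1-yl in place of bromo on an aromatic carbon. Among the compounds with values here, the one measured step at this place is large: a number 2.84 log units lower from compound 2 to compound 3 (beyond the scatter), with bromo in place of isopropyl. Compound 1 carries the same hex-1-yn-1-yl at that place and reads 2.98. A large rise in this assay is therefore expected, with the estimated change a number 2.95 log units higher from compound 3 to compound 4 (beyond the scatter). Compound 4 is estimated at 2.95, with an expected range of 2.4 to 3.5.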

Compound 4, distribution coefficient: 2.45
Compound 4: the middle estimate sits 0.50 log units above what was measured, and the stated range covers the measured number.
By their numbers in this assay, from the lowest: compound 3; then compound 4; then compounds 2 and 1 (each within the scatter of the next).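

In this assay, hex-1-yn-1-yl at this position recovers most of the drop seen with bromo: a number 2.45 log units higher from compound 3 to compound 4 (beyond the scatter). Yet it does not match isopropyl on this core, with a number 0.39 log units lower from compound 2 to compound 4 (beyond the scatter), while the first look at methoxy in place of hydrogen on an aromatic carbon gives a number 0.53 log units lower from compound 1 to compound 4 (beyond the scatter). Nothing available here explains these shifts.

From the compounds shown here alone, how an amine or a carboxylic acid would read at this position stays open. So does whether the methoxy step holds with groups other than hex-1-yn-1-yl at this position.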